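The compounds below may be only part of what the source reports. "The series", "measured", "known", "first", "only" and "open" are said of these compounds alone.

Going by the values given here, in a physicochemical assay for solubility, in phosphate buffer, with a stated time of 24 h, at pH 7.4, tested at 100 uM (a lower number here means a less soluble compound, a higher number a more soluble compound), only two related compounds have numbers so far. Compound 1 (`O=C(NCc1ccc(S(=O)(=O)c2ccccc2)cc1)N1Cc2cccnc2C1`) gives 144000 nM and compound 2 (`O=C(NCc1ccc(S(=O)(=O)c2cncc(C(F)(F)F)c2)cc1)N1Cc2ccncc2C1`) gives 83000 nM, so compound 2 stands within the usual scatter of compound 1. These two compounds differ in more than one place, so they do not isolate the effect of any single group.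

Compound 3 (`O=C(NCc1ccc(S(=O)(=O)C2CCC(F)(F)CC2)cc1)N1Cc2ccncc2C1`) keeps the rest of compound 2 and changes one group: 4,4-difluorocyclohexyl in place of 5-(trifluoromethyl)pyridin-3-yl on a sulfonyl sulfur. Here 4,4-difluorocyclohexyl stands in place of 5-(trifluoromethyl)pyridin-3-yl on a sulfonyl sulfur, so a six-membered aromatic ring gives way to a six-membered non-aromatic ring. Among the compounds with values here, no measured pair shows a change of this kind, so the expectation is uncertain, with no firm direction and no shift beyond the scatter. The estimate amounts to a step of a 1.2-fold lower number from compound 2 to compound 3 (0.07 log units; within the scatter). Compound 3 is expected at 70000 nM, with an estimated range of 25000 nM to 150000 nM.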

Compound 3, solubility: 35000 nM
The estimate for compound 3 lay 2.0-fold (0.30 log units) above the measured number, and the stated range covers the measured number.
By their numbers in this assay, from the lowest: compound 3; then compounds 2 and 1 (each within the scatter of the next).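

On a sulfonyl sulfur whose other neighbour is an aromatic carbon, the choice of group shows up in this assay: 4,4-difluorocyclohexyl in place of 5-(trifluoromethyl)pyridin-3-yl gives a 2.4-fold lower number from compound 2 to compound 3 (0.38 log units; beyond the scatter) and so moves the number beyond the scatter. Going by these compounds alone, this is the only comparison here that changes a single place, so it is the only direct reading of this position, and the step is modest. No measurement shown here accounts for the step.

The change swaps an aromatic ring for a non-aromatic one, removes the ring nitrogen and alters the fluorine count all at once, so the compounds shown cannot separate these differences. Plain cyclohexyl or a piperidine ring on the same sulfonyl sulfur would help pull them apart.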